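From bromo to nitro: one more aromatic group

The source may hold more compounds than are shown below. What is called first, only, known or untested is meant among the compounds shown, and "the series" means these compounds.

Measured in a functional assay on the whole organism with Mus musculus as the target, in the maximal electroshock model; on this read-out lower numbers stand for an effect already at smaller amounts and higher numbers for an effect only at larger amounts of compound:

Compound 1 `O=C(Cc1ccccc1)NS(=O)(=O)C(F)(F)F`: 6.2 mg/kg
Compound 2 `O=C(Cc1ccc(Cl)cc1)NS(=O)(=O)C(F)(F)F`: 7.6 mg/kg
Compound 3 `O=C(Cc1ccc(Br)cc1)NS(=O)(=O)C(F)(F)F`: 23 mg/kg

Compound 3 stands highest of the three on this assay, and its steps from both other compounds lie beyond the scatter. The next compound, compound 4 `O=C(Cc1ccc([N+](=O)[O-])cc1)NS(=O)(=O)C(F)(F)F`, has not yet been measured. It carries nitro in place of bromo on an aromatic carbon, para to a large group (nitro in place of bromo on an aromatic carbon).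

Among the compounds with values here, three measured steps bear on this change. Chloro in place of hydrogen gave a 1.2-fold higher number from compound 1 to compound 2 (0.09 log units; within the scatter). Bromo in place of hydrogen gave a 3.7-fold higher number from compound 1 to compound 3 (0.57 log units; beyond the scatter), and bromo in place of chloro gave a 3.0-fold higher number from compound 2 to compound 3 (0.48 log units; beyond the scatter). Within the data shown here, these steps show that the group at this place can matter, but only modestly, and bromo is the only group that moved the number beyond the scatter. Among the measured compounds shown here, no nitro compound has been measured, so the direction of the change remains uncertain. Compound 3 already lies at the high end, which gives a slight lean toward a lower number. The expected change is a 1.8-fold lower number from compound 3 to compound 4 (0.25 log units; within the scatter), so no step beyond the scatter is expected. For compound 4 the estimated value is 13 mg/kg, with an expected range from 5 mg/kg to 35 mg/kg.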

Compound 4, dose for half-maximal effect: 12 mg/kg
Compound 4: middle estimate off by 1.1-fold (0.03 log units), on the high side, within the range that was stated.
By their numbers in this assay, from the lowest: compounds 1, 2, 4 and 3 (each within the scatter of the next, the first and the last beyond it).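

In this assay, nitro puts more heavy atoms at this place than bromo and brings hydrogen-bond acceptors that bromo lacks, yet a 1.9-fold lower number from compound 3 to compound 4 (0.28 log units; within the scatter) stays inside the scatter, as do a 1.6-fold higher number from compound 2 to compound 4 (0.20 log units; within the scatter) and a 1.9-fold higher number from compound 1 to compound 4 (0.29 log units; within the scatter) on the other side. Compound 4 thus sits within the scatter of all three earlier compounds, whereas compound 3 is beyond it from both compound 1 and compound 2, so among these four groups bromo remains the only one set apart from hydrogen, and a count of heavy atoms or acceptors does not order the numbers. No measurement shown here accounts for the result at this position.

Whether the step with bromo is an isolated case or part of a wider dependence on the group at this place stays open, since only hydrogen, chloro, bromo and nitro are shown there. An amine, a carboxylic acid or a methoxy group on the same aromatic carbon could show whether other groups stay close to compound 1 or move as far as bromo does.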